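From 2,4-dichlorophenyl to 3,5-dichlorophenyl: what to expect

The source may report more compounds than this note shows. Statements on the series, on what has been measured and on what is new or still open speak of the compounds shown alone.

Measured so far:
Compound 1 `COc1cccc(/C=C2\CCC/C(=C\c3cccc(OC)c3OC)C2=O)c1`: 16400 nM
Compound 2 `COc1cccc(/C=C2\CCC/C(=C\c3ccc(Cl)cc3Cl)C2=O)c1OC`: > 20000 nM (a limit, not a number)

Both compounds were tested in a functional assay on A549 cells (Homo sapiens) for cytotoxicity, read by MTT assay, with a stated time of 72 h; on this read-out higher numbers stand for weaker inhibition and lower numbers for stronger inhibition. Compound 1 gives 16400 nM as a true number. Compound 2 gives only a limit, > 20000 nM, and not a number. Its place on the scale is therefore marked only by the limit of > 20000 nM in this assay, at which 1 of the 2 values shown sits, and by nothing firmer.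

Compound 3 `COc1cccc(/C=C2\CCC/C(=C\c3cc(Cl)cc(Cl)c3)C2=O)c1OC` has the same atoms as compound 2, joined differently: 3,5-dichlorophenyl in place of 2,4-dichlorophenyl on a double-bonded chain carbon bound to a double-bonded ring carbon is the whole change, with 3,5-dichlorophenyl in place of 2,4-dichlorophenyl.

Among the measured compounds shown here, only one measured step touches this place. It is an at least 1.2-fold higher number from compound 1 to compound 2 (0.08 log units; that floor lies within the scatter), and it stays within the usual scatter. For the measured compounds named here, no measured pair shows what happens when the two chlorine atoms sit elsewhere on the ring. So no step beyond the scatter is expected in this assay, and no direction can be argued. The estimated step is an at least 1.1-fold lower number from compound 2 to compound 3 (0.04 log units; that floor lies within the scatter). Compound 3 is expected at 18000 nM, with an estimated range from 8000 nM to 40000 nM as the likely span.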

Compound 3, half-maximal inhibitory concentration: 12500 nM
For compound 3 the middle estimate is 1.4-fold (0.16 log units) above the measured one; the range from low to high includes it.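

In this assay, compound 3 gives 12500 nM, a true number for a dichlorophenyl group at this position on a double-bonded chain carbon bound to a double-bonded ring carbon, and moving the two chlorine atoms gives an at least 1.6-fold lower number from compound 2 to compound 3 (0.20 log units; that floor lies within the scatter). Replacing 3-methoxyphenyl with 3,5-dichlorophenyl gives a 1.3-fold lower number from compound 1 to compound 3 (0.12 log units; within the scatter), so this swap of one ring for another shows no clear effect on the read-out, and the measured numbers stay weak. The real size of the step from the 2,4-dichlorophenyl compound cannot be fixed, because compound 2 has only a limit and not a number: the limit of > 20000 nM in this assay, at which 1 of the 3 values shown sits.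

A ring with a single chlorine, such as 4-chlorophenyl, would show whether one chlorine atom behaves like two at this place, and the compounds shown do not settle that. Also open, on these data alone, is whether a very different group here, such as a carboxylic acid or a dimethylamino group on the ring, would move the number beyond the usual scatter of repeated measurements.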